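The source may report more compounds than this note shows. Statements on the series, on what has been measured and on what is new or still open speak of the compounds shown alone.

Measured in an assay on isolated protein for binding affinity to vitamin D3 receptor (Homo sapiens), read by fluorescence polarization, tested at 1 uM; a higher number here means more inhibition at the concentration tested (going by the name of the read-out), a lower number less inhibition:
Compound 1 `CCCC(O)(C#Cc1ccc(C(CC)(CC)C2=CN(CC)C(C(=O)NCCN(CC)CC)C2)cc1C)CCC` gives 51.1%.
Compound 2 `CCN(CC)CCNC(=O)C1CC(C(CC)(CC)c2ccc(C#CC(O)C3CCCCC3)c(C)c2)=CN1CC` gives 44.2%.
Compound 3 `CCN(CC)CCNC(=O)C1CC=C(C(CC)(CC)c2ccc(C#CC(C)(O)CC)c(C)c2)N1CC` gives 63.4%.

Of the three, compound 3 stands highest in this assay, and its lead over compound 1 and over compound 2 lies beyond the scatter. Compound 4 `CCN(CC)CCNC(=O)C1CC=C(C(CC)(CC)c2ccc(C#CC(O)C3CCCC3)c(C)c2)N1CC` differs from compound 3 in one place: cyclopentyl(hydroxy)methyl in place of 1-hydroxy-1-methylpropyl on a triple-bonded carbon. Among the measured compounds shown here, one measured step bears on this change, the one in which a ring-bearing alcohol replaced an open-chain one at the same place: a number 6.9 percentage points lower from compound 1 to compound 2 (within the scatter), a step within the scatter. On that basis a change of similar kind is expected for compound 4, a step of a number 6.4 percentage points lower from compound 3 to compound 4 (within the scatter) that should stay within the usual scatter. Compound 4 is therefore estimated at 57%, with a likely range from 42% to 72%.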

Compound 4, a percentage reported as inhibition, at one concentration (the size of the read-out at that concentration, not a potency): 47.9%
The estimate for compound 4 lay 9.1 percentage points above the measured number, within the range that was stated.
By their numbers in this assay, from the lowest: compounds 2, 4 and 1 (each within the scatter of the next); then compound 3.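

In this assay the move from 1-hydroxy-1-methylpropyl to cyclopentyl(hydroxy)methyl on the triple-bonded carbon gives a number 15.5 percentage points lower from compound 3 to compound 4 (beyond the scatter), so at this place a ring-bearing alcohol can cost inhibition beyond the scatter, which the earlier step, a number 6.9 percentage points lower from compound 1 to compound 2 (within the scatter), did not show. The two groups carry the same hydrogen-bond donor and acceptor counts, so the change does not alter those counts. Nothing available here accounts for this drop. From the compounds shown here alone, it remains open whether an open-chain alcohol with the same carbon count as cyclopentyl(hydroxy)methyl would behave like the ring. Going by these compounds, it is equally open how an amine in place of the hydroxyl would read.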